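Guanidine series: chloro substitution and atrial agonist response

The source may report more compounds than this note shows. Statements on the series, on what has been measured and on what is new or still open speak of the compounds shown alone.

compound 1 `N=C(NCCCc1c[nH]cn1)NCCSC(c1ccccc1)c1ccccn1` — 1
compound 2 `N=C(NCCCc1c[nH]cn1)NCCC(c1ccccc1)c1ccccn1` — 1

In a functional assay on cardiac atrium for agonist activity at histamine H2 receptor (Cavia porcellus) (a lower number here means a smaller maximal response, a higher number a larger maximal response), compound 1 gives 1. In this assay compound 2 gives 1, level with compound 1 at the digits shown and within the scatter of it. Both reach the reference level.

Compound 3 `N=C(NCCCc1c[nH]cn1)NCCC(c1ccc(Cl)cc1)c1ccccn1` is not yet measured in this assay. It differs from compound 2 by chloro in place of hydrogen on an aromatic carbon. Within the data shown here, no measured pair shows this change, so the expectation rests on compounds 1 and 2 alone. The expected step a number 0.050 lower from compound 2 to compound 3 (within the scatter) is none beyond the scatter, with a small loss possible. Compound 3 is estimated at 0.95, range 0.75 to 1.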

Compound 3, intrinsic activity: the largest response reached, as a fraction of the reference agonist's: 1
Compound 3: the middle estimate sits 0.050 below what was measured, and the stated range covers the measured number.
By their numbers in this assay, from the lowest: compounds 1, 2 and 3 (each within the scatter of the next).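

Chloro in place of hydrogen on an aromatic carbon, para to a large group, is the first substitution on this ring in the series, and in this assay it gives no change at the digits printed from compound 2 to compound 3 (within the scatter). This place therefore accepts one chlorine atom with the maximal response held, though a ceiling at the reference level could hide any difference among these compounds. No available evidence bears on this result.

Open, going by these compounds, is whether a methoxy group, an amine or a carboxylic acid at the same place holds the response. A single phenyl to 4-chlorophenyl pair also leaves open whether chloro behaves alike on the core of compound 1.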